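The source may report more compounds than this note shows. Statements on the series, on what has been measured and on what is new or still open speak of the compounds shown alone.

The compounds measured in a functional assay on SK-OV-3 cells (Homo sapiens) (a lower number here means a stronger inhibitor of growth, a higher number a weaker inhibitor of growth), are these:
- compound 1 `N#Cc1ccc(/C=C/S(=O)(=O)Cc2ccc(Nc3ncnc4ccccc34)cc2)cc1` gives > 100000 nM (a limit of the assay)
- compound 2 `O=S(=O)(/C=C/c1ccc(Br)cc1)Cc1ccc(Nc2ncnc3ccccc23)cc1` gives 1000 nM
- compound 3 `CC(C)(C)c1cc(/C=C/S(=O)(=O)Cc2ccc(Nc3ncnc4ccccc34)cc2)cc(C(C)(C)C)c1O` gives 3000 nM

Compound 2 has the lowest number of those shown (1000 nM). Compound 3 follows with a higher number (3000 nM), a gap beyond the scatter. Compound 1 reached only a limit of the assay (> 100000 nM).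

The next compound is compound 4 `O=S(=O)(/C=C/c1ccc(C(F)(F)F)cc1F)Cc1ccc(Nc2ncnc3ccccc23)cc1`, not yet measured. It differs from compound 2 at a single place: 2-fluoro-4-(trifluoromethyl)phenyl in place of 4-bromophenyl on a double-bonded chain carbon bound to a double-bonded chain carbon. In words, 2-fluoro-4-(trifluoromethyl)phenyl stands in place of 4-bromophenyl on a double-bonded chain carbon bound to a double-bonded chain carbon.

Among the measured compounds shown here, the one measured step on this aromatic group is large (an at least 100-fold lower number from compound 1 to compound 2 (2.00 log units; beyond the scatter)). It shows that a single replacement there can shift the number strongly, though it involves a different pair of groups. Neither other compound in the series gives a lower number than compound 2 (1000 nM), so a modest move towards weaker inhibition is expected, with wide uncertainty. The expected step is a 2.5-fold higher number from compound 2 to compound 4 (0.40 log units; beyond the scatter). For compound 4 the estimated value is 2500 nM, with an expected range from 500 nM to 20000 nM.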

Compound 4, concentration for 50% growth inhibition: 39000 nM
Beside the measured number, compound 4's estimate is 16-fold (1.19 log units) below it; measured number above the stated range.
By their numbers in this assay, from the lowest: compound 2; then compound 3; then compound 4. At a limit, above all of these: compound 1.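

Replacing 4-bromophenyl with 2-fluoro-4-(trifluoromethyl)phenyl on a double-bonded chain carbon bound to a double-bonded chain carbon is costly in this assay: a 39-fold higher number from compound 2 to compound 4 (1.59 log units; beyond the scatter). This shows that a second, quite different group at this place also falls far short of the 4-bromophenyl of compound 2, so the large loss is not confined to the 4-cyanophenyl group, while the new group still improves on that one, an at least 2.5-fold lower number from compound 1 to compound 4 (0.40 log units; beyond the scatter). That step can only be read as a minimum, as compound 1 gives a limit and not a number: the limit of > 100000 nM in this assay, at which 1 of the 4 values shown sits.

The fluoro and the trifluoromethyl enter together, and the compounds shown do not separate their contributions. They also leave open how a 4-(trifluoromethyl)phenyl, a 2-fluorophenyl or a 4-chlorophenyl group would stand at this place.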